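This account rests on a few compounds, and the source may have more. Where it says the series, first, only, none or still open, it means among the compounds named here.

Measured so far:
compound 1, `Cc1ccc(C#Cc2cn(C/C=C\CN3C(=O)c4ccccc4C3=O)c(=O)[nH]c2=O)cc1` — 266000 nM
compound 2, `CCCCCCC#Cc1cn(C/C=C/CN2C(=O)c3ccccc3C2=O)c(=O)[nH]c1=O` — 35000 nM

In a functional assay on MOLT-4 cells (Homo sapiens) for antiproliferative activity, read by MTT assay, with a stated time of 3 days (on this read-out higher numbers stand for weaker inhibition and lower numbers for stronger inhibition), compound 1 gives 266000 nM, the highest of the two numbers recorded. The nearest neighbour, compound 2, gives 35000 nM in this assay, a lower number than that of compound 1, and the gap between the two lies beyond the usual scatter. Within the data shown here, compound 2 differs from compound 1 in more than one place, so the two values show only that a related compound reaches a lower number.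

Compound 3, `CCCCCc1ccc(C#Cc2cn(C/C=C\CN3C(=O)c4ccccc4C3=O)c(=O)[nH]c2=O)cc1`, is built from compound 1 by butyl in place of hydrogen on a saturated chain carbon bound to an aromatic carbon. Among the measured compounds shown here, no measured pair isolates this single change, so the size of its effect in this assay is open. A modest move toward a lower number is expected, with the step estimated as a 2.4-fold lower number from compound 1 to compound 3 (0.38 log units; beyond the scatter). For compound 3 the expected value in this assay is 110000 nM, with a range from 30000 nM to 300000 nM.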

Compound 3, half-maximal inhibitory concentration: 30000 nM
Estimate against measurement, compound 3: 3.7-fold (0.56 log units) above; the range from low to high includes it.
By their numbers in this assay, from the lowest: compounds 3 and 2 (each within the scatter of the next); then compound 1.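

In this assay, butyl in place of hydrogen on a saturated chain carbon bound to an aromatic carbon gives an 8.9-fold lower number from compound 1 to compound 3 (0.95 log units; beyond the scatter), so the change from 4-methylphenyl to 4-pentylphenyl goes with stronger inhibition. Among these compounds, this is the only comparison here that isolates a single change, as the values of the earlier two compounds differ in more than one place and could not be tied to any one group. Nothing measured here accounts for the size of this step.

Going by these compounds, it remains open whether a longer chain, such as octyl, would move the number further in this assay, or whether a shorter one, such as ethyl, would already bring much of this step. Also open, on these data alone, is how an amine or a carboxylic acid at the end of the pentyl chain would read.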